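A few compounds are considered here, and "the series" means these few. Any claim that something is new, unique, unknown or untested is made for them only; others in the source may bear on it.

Measured so far:
Compound 1 `O=C1CN(Cc2ccc(-c3ccc(F)c(CN4CCCCC4)n3)cc2)C(=O)N1CC1CCC1`: 0.0833 h
Compound 2 `CC(C)CN1C(=O)CN(Cc2ccc(-c3ccc(F)c(CN4CCCCC4)n3)cc2)C1=O`: 0.217 h

Both numbers come from an in vitro ADME assay on microsomes from liver (Homo sapiens) for metabolic stability, read by LC-MS, using NADPH, tested at 1 uM (on this read-out higher numbers stand for a longer-lived compound and lower numbers for a shorter-lived compound), and compound 2 gives the higher of the two. Among the compounds with values here, the one measured step, a 2.6-fold higher number from compound 1 to compound 2 (0.42 log units; beyond the scatter), shows how much that read-out moved when one small group was swapped for another at the same place. Compound 3 `O=C1CN(Cc2ccc(-c3ccc(F)c(CN4CCCCC4)n3)cc2)C(=O)N1CC1CC1` differs from compound 2 by a single change, (cyclopropyl in place of isopropyl on a saturated chain carbon bound to an amide-type nitrogen in a ring). The measured step went from a three-membered-ring relative, cyclobutyl, to the open isopropyl and rose; the new step goes from isopropyl back to a ring, cyclopropyl. Within the data shown here, no pair of measured compounds shows cyclopropyl against isopropyl directly, so the size is uncertain. A modest downward step in this assay is expected, a 1.4-fold lower number from compound 2 to compound 3 (0.16 log units; within the scatter), though an outcome within the scatter would not surprise. Compound 3 is estimated at 0.15 h, with a range from 0.06 h to 0.4 h.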

Compound 3, half-life in the Homo sapiens assay: 0.333 h
Estimate against measurement, compound 3: 2.2-fold (0.35 log units) below; measured number inside the range.
By their numbers in the Homo sapiens assay, from the lowest: compound 1; then compounds 2 and 3 (each within the scatter of the next).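

Swapping isopropyl for cyclopropyl keeps the count of heavy atoms and adds a ring, and in the Homo sapiens assay it gives a 1.5-fold higher number from compound 2 to compound 3 (0.19 log units; within the scatter), while the two rings on this same carbon differ clearly, with a 4.0-fold higher number from compound 1 to compound 3 (0.60 log units; beyond the scatter). So at this position ring size separates compounds, whereas the open isopropyl and the cyclopropyl ring cannot be told apart on half-life. In a physicochemical assay for lipophilicity (a higher number here means a more lipophilic compound, a lower number a more polar compound), compound 2 gives 3.4 and compound 3 gives 2.8, so the swap to cyclopropyl makes the compound more polar even though its half-life stays within the scatter: the measured distribution coefficient of compound 2, 3.4, and of compound 3, 2.8, a number 0.60 log units lower (beyond the scatter)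

What the compounds shown leave open is how an oxetane ring, an amine or a longer chain would behave at this place in the Homo sapiens assay. With only these three groups, no trend with ring size can be drawn.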